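The source may report more compounds than this note shows. Statements on the series, on what has been measured and on what is new or still open speak of the compounds shown alone.

Measured compounds so far:

- Compound 1, `COc1cc(C)c(C(=O)O[C@H]2[C@@H](O)[C@H](O[C@H]3CC[C@H](C)[C@@H]4[C@@H]3C=C(C)[C@H]3/C(C)=C/CC/C(C)=C/[C@]5(C)C=C(C(=O)O)[C@H](C)C[C@]56OC(=O)C(=C6O)C(=O)[C@@]43C)O[C@H](C)[C@H]2O)c(O)c1`; in a toxicity assay on SW-620 cells (Homo sapiens) for cytotoxicity, read by MTT assay, with a stated time of 48 h (a lower number here means a stronger inhibitor, a higher number a weaker inhibitor), compound 1 gives > 30000 nM, which is a limit of the assay and not a number.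
- Compound 2, `COc1cc(C)c(C(=O)O[C@H]2[C@H](O[C@H]3CC[C@H](C)[C@@H]4[C@@H]3C=C(C)[C@H]3/C(C)=C/CC/C(C)=C/[C@@H]5C=C(C(=O)O)[C@H](C)C[C@]56OC(=O)C(=C6O)C(=O)[C@@]43C)O[C@H](C)[C@@H](O)[C@H]2O)c(O)c1`; in this assay compound 2 gives > 30000 nM, again a limit of the assay.
- Compound 3, `CC1=C[C@@]2(C)/C=C(\C)CC/C=C(\C)[C@@H]3C(C)=C[C@H]4[C@@H]([C@@H](C)CC[C@@H]4O)[C@]3(C)C(=O)C3=C(O)[C@@]2(C[C@H]1C)OC3=O`; in this assay compound 3 gives > 30000 nM, also a limit of the assay.

For the measured compounds named here, compound 3 therefore stands nowhere in particular on these numbers: it shares the limit of > 30000 nM in this assay, at which 3 of the 3 values shown sit, with the other two, and no step between measured compounds can be drawn, since none of the three half-maximal inhibitory concentrations is a number.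

The next compound is compound 4, `CC(=O)O[C@H]1CC[C@H](C)[C@@H]2[C@@H]1C=C(C)[C@H]1/C(C)=C/CC/C(C)=C/[C@]3(C)C=C(C)[C@H](C)C[C@]34OC(=O)C(=C4O)C(=O)[C@@]21C`. It differs from compound 3 in one place: acetyl in place of hydrogen on an oxygen on a saturated carbon. Going by the values given here, nothing among the measured compounds shows what such a change does in this assay; all that the series shows is that three variations of the shared core sit at the same limit.

On that basis no step beyond the scatter is expected from compound 3 to compound 4, and the most likely outcome for compound 4 is again a limit rather than a number. The estimate for compound 4 in this assay is 30000 nM, within 10000 nM to 100000 nM, which is expected to mean a step of a number no higher from compound 3 to compound 4 (the limit leaves the size open).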

Compound 4, half-maximal inhibitory concentration: > 30000 nM
Compound 4 was reported as a limit (the forecaster's own chance of this, stated with the estimate: 75%); the middle value lies on the limit itself.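

In this assay compound 4 gives > 30000 nM, a limit of the assay and not a number. Compound 3 also sits at a limit, and no step can be read between compound 3 and compound 4. All four compounds share one reading: the limit of > 30000 nM in this assay, at which 4 of the 4 values shown sit.

The compounds shown leave open what hydroxy to acetoxy does to the half-maximal inhibitory concentration on the shared core.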